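Third methoxy on the chalcone ring of compound 2

A few compounds are considered here, and "the series" means these few. Any claim that something is new, unique, unknown or untested is made for them only; others in the source may bear on it.

Compound 2 `COc1ccc(/C=C/C(=O)c2c(C)[n+]([O-])c3ccccc3[n+]2[O-])cc1OC` gives 18500 nM in a functional assay on MOLT-4 cells (Homo sapiens) for inhibition, with a stated time of 3 days (on this read-out higher numbers stand for weaker inhibition and lower numbers for stronger inhibition), the lowest of the two numbers measured, with compound 1 `COc1ccc(/C=C/C(=O)c2c(C)[n+]([O-])c3ccccc3[n+]2[O-])cc1` nearest at 25800 nM; the two lie within the scatter of each other. Compound 3 `COc1cc(/C=C/C(=O)c2c(C)[n+]([O-])c3ccccc3[n+]2[O-])cc(OC)c1OC` differs from compound 2 by methoxy in place of hydrogen on an aromatic carbon, ortho to a methoxy group and meta to a methoxy group. Within the data shown here, the one step that bears on this change is the same kind of addition from compound 1 to compound 2, which brought a 1.4-fold lower number from compound 1 to compound 2 (0.14 log units; within the scatter), a shift within the scatter. On that basis no step beyond the scatter is expected in this assay from compound 2 to compound 3, and a change of about a 1.2-fold lower number from compound 2 to compound 3 (0.09 log units; within the scatter) is estimated. Compound 3 is therefore expected to give about 15000 nM, most likely between 6000 nM and 40000 nM.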

Compound 3, half-maximal inhibitory concentration: 5510 nM
Estimate against measurement, compound 3: 2.7-fold (0.43 log units) above, and the stated range ends above it.
By their numbers in this assay, from the lowest: compound 3; then compounds 2 and 1 (each within the scatter of the next).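

In this assay the methoxy added at this position, ortho to a methoxy group and meta to a methoxy group, gives a 3.4-fold lower number from compound 2 to compound 3 (0.53 log units; beyond the scatter) while the earlier addition of the same group gave a 1.4-fold lower number from compound 1 to compound 2 (0.14 log units; within the scatter) and stayed within the scatter. Among these compounds, the same swap of hydrogen for methoxy on the same aromatic ring therefore does not count equally at every place: only this one produces a step beyond the scatter. Nothing available here accounts for that difference.

As far as these compounds go, it remains open whether the step belongs to methoxy at this place alone or to the three methoxy groups taken together. An ethoxy group, a hydroxyl group or an amine at this position would show how specific the step is to methoxy.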